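Compound 4: a Smaller Side Group on the Amide Nitrogen

This account rests on a few compounds, and the source may have more. Where it says the series, first, only, none or still open, it means among the compounds named here.

Three measured compounds share one core and differ in their side groups. In an ADME assay on HEK293 cells for agonist activity at metabotropic glutamate receptor 5 (Rattus norvegicus), read by fluorescence and calcium flux (on this read-out higher numbers stand for larger maximal responses and lower numbers for smaller maximal responses), compound 1 `C[C@@H](NC(=O)c1ccc(C#Cc2ccc(F)cc2)cn1)C(C)(C)O` gives 38.4%, compound 2 `C[C@@H](NC(=O)c1ccc(C#Cc2cccc(F)c2)nc1)C(C)(C)O` gives 26.6% and compound 3 `C[C@@H](NC(=O)c1ccc(C#Cc2cccc(F)c2)cn1)C(C)(C)C` gives 31.2%. Compound 3 holds the second highest of the three numbers, yet its gap to compound 2 and its gap to compound 1 both lie within the usual scatter, so no order among the three can be claimed. Compound 4 `CC(C)(CO)NC(=O)c1ccc(C#Cc2cccc(F)c2)cn1` is not yet measured. It differs from compound 3 in one place: 1-(hydroxymethyl)-1-methylethyl in place of 1,2,2-trimethylpropyl on an amide-type nitrogen. For the measured compounds named here, no measured pair shows this change, so the step from compound 3 to compound 4 is expected to stay within the scatter. Compound 4 is estimated to reach 30%, between 15% and 45%, an expected step of a number 1.2 percentage points lower from compound 3 to compound 4 (within the scatter).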

Compound 4, largest response reached (reported as efficacy), in percent of the reference or control that the assay uses: 9.3%
Estimate against measurement, compound 4: 20.7 percentage points above; measured number outside the range, below it.
By their numbers in this assay, from the lowest: compound 4; then compounds 2, 3 and 1 (each within the scatter of the next, the first and the last beyond it).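

In this assay, for the compounds shown here, this is the first change in a single place whose size can be read: a number 21.9 percentage points lower from compound 3 to compound 4 (beyond the scatter). The maximal response therefore depends on the group on this amide-type nitrogen, and replacing 1,2,2-trimethylpropyl with 1-(hydroxymethyl)-1-methylethyl is not a neutral swap, at least for this one pair. No evidence here accounts for the drop.

The compounds shown leave open which part of the change matters: the oxygen, the shorter side group or the lost stereocentre. On these data alone, how an amine in place of the hydroxyl, or a longer chain, would read on this nitrogen also stays open.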